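A few compounds are considered here, and "the series" means these few. Any claim that something is new, unique, unknown or untested is made for them only; others in the source may bear on it.

Measured so far:
compound 1, `CCCc1nc(-c2ccccc2)c(CNCCCN2CCN(c3ccccc3OC)CC2)o1`, 41%;
compound 2, `CCCc1nc(-c2ccccc2)c(CNCCCN2CCN(c3ccccc3F)CC2)o1`, 54.4%;
compound 3, `CCCc1nc(-c2ccccc2)c(CNCCCN2CCN(c3cccc(C)c3C)CC2)o1`, 55.2%.

All three were tested in an assay on HEK293 cells for inhibition of Voltage-dependent T-type calcium channel subunit alpha-1G (Homo sapiens), read by fluorescence, tested at 10 uM; on this read-out lower numbers stand for less inhibition and higher numbers for more inhibition at the one concentration tested (going by the name of the read-out). Compound 3 stands at the top of the three numbers, though its lead over compound 2 is only a number 0.8 percentage points higher from compound 2 to compound 3 (within the scatter), a step within the scatter, so the two cannot be put in order. Against compound 1 the gap is clearer: a number 14.2 percentage points higher from compound 1 to compound 3 (beyond the scatter), and compound 2 likewise sits above compound 1 by a number 13.4 percentage points higher from compound 1 to compound 2 (beyond the scatter).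

Compound 4, `CCCc1nc(-c2ccccc2)c(CNCCCN2CCN(c3ccccc3C(F)(F)F)CC2)o1`, is the next compound to be measured. It differs from compound 3 in one place: 2-(trifluoromethyl)phenyl in place of 2,3-dimethylphenyl on an amine nitrogen in a ring. The step that bears most directly on it is the exchange of one aryl group for another on the ring nitrogen, which from compound 2 to compound 3 gave a number 0.8 percentage points higher from compound 2 to compound 3 (within the scatter), a change that did not leave the scatter. The only sizeable movement among the three, a number 14.2 percentage points higher from compound 1 to compound 3 (beyond the scatter), belongs to the replacement of the methoxy-bearing aryl group, which is not involved here. The expectation for compound 4 is therefore a step of a number 3.2 percentage points lower from compound 3 to compound 4 (within the scatter) in this assay, that is, nothing beyond the scatter. Compound 4 is estimated to give 52%, with a range from 35% to 70%.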

Compound 4, a percentage reported as inhibition, at one concentration (the size of the read-out at that concentration, not a potency): 45%
Estimate against measurement, compound 4: 7 percentage points above; low and high end bracket the measured number.
By their numbers in this assay, from the lowest: compounds 1, 4, 2 and 3 (each within the scatter of the next, the first and the last beyond it).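

In this assay, the exchange of one aryl group for another on the ring nitrogen now proves able to leave the scatter: 2-(trifluoromethyl)phenyl in place of 2,3-dimethylphenyl gave a number 10.2 percentage points lower from compound 3 to compound 4 (beyond the scatter), whereas the earlier exchange of 2-fluorophenyl for 2,3-dimethylphenyl gave only a number 0.8 percentage points higher from compound 2 to compound 3 (within the scatter). The other two comparisons do not extend this to a clear ranking of the groups, since trifluoromethyl in place of fluoro gave a number 9.4 percentage points lower from compound 2 to compound 4 (within the scatter) and trifluoromethyl in place of methoxy gave a number 4 percentage points higher from compound 1 to compound 4 (within the scatter), so the three compounds carrying a single group on the aryl ring can be separated only at the ends, with compound 1 and compound 2 apart while compound 4 stays within the scatter of each. Nothing in the available data bears on why this change moved the number.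

The compounds shown leave open how a nitrile, a chloro group or a carboxylic acid on this aryl group would stand in this assay. They also leave open what an amide in place of the amine in the linking chain, or a longer chain at that link, would do to the number.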